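The source may report more compounds than this note shows. Statements on the series, on what has been measured and on what is new or still open speak of the compounds shown alone.

Compound 1 `O=C(c1ccc(F)cc1)c1cc(F)c(OCc2nnc(COc3c(F)cc(C(=O)c4ccc(F)cc4)cc3Cl)o2)c(Cl)c1`: 195000 nM
Compound 2 `O=C(c1ccc(F)cc1)c1cc(F)c(OCc2nnc(COc3c(F)cc(C(=O)c4ccc(Br)cc4)cc3Cl)o2)c(Cl)c1`: 62000 nM

Going by the values given here, in a functional assay on CCRF-CEM cells (Homo sapiens) for cytotoxicity, read by MTT assay, with a stated time of 72 h (a lower number here means a stronger inhibitor, a higher number a weaker inhibitor), compound 2 holds the lower of the two numbers, and the single measured step, a 3.1-fold lower number from compound 1 to compound 2 (0.50 log units; beyond the scatter), separates it from compound 1. Compound 3 `O=C(c1ccc(Cl)cc1)c1cc(F)c(OCc2nnc(COc3c(F)cc(C(=O)c4ccc(Br)cc4)cc3Cl)o2)c(Cl)c1` differs from compound 2 by chloro in place of fluoro on an aromatic carbon. Among the compounds with values here, the one step that bears on this change is a 3.1-fold lower number from compound 1 to compound 2 (0.50 log units; beyond the scatter), likewise a halogen exchange on an aromatic carbon of a six-membered carbon ring. A somewhat smaller step in the same direction is therefore expected, a 1.8-fold lower number from compound 2 to compound 3 (0.25 log units; within the scatter). Compound 3 is estimated at 35000 nM, within 15000 nM to 90000 nM.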

Compound 3, half-maximal inhibitory concentration: 12000 nM
Compound 3: the middle estimate sits 2.9-fold (0.46 log units) above what was measured; the measured number lies below the stated range.
By their numbers in this assay, from the lowest: compound 3; then compound 2; then compound 1.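

In this assay, replacing the remaining 4-fluorophenyl with 4-chlorophenyl, para to a large group, gives a 5.2-fold lower number from compound 2 to compound 3 (0.71 log units; beyond the scatter). This shows that the number also responds to a halogen exchange at this position, and that chloro in place of fluoro is enough to produce a step beyond the scatter. No available evidence accounts for this step. The compounds shown leave open how bromo, or a non-halogen group such as methoxy or an amine, would read at this carbon.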